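Swapping the Sulfonyl Substituent: Cyclohexyl to Diethylamino

The compounds below may be only part of what the source reports. "The series", "measured", "known", "first", "only" and "open" are said of these compounds alone.

Compound 1 `COCCS(=O)(=O)N1CCN(c2ccc(OCC3CCN(C(=O)OC(C)C)CC3)cn2)CC1` in a functional assay on CHO-K1 cells for agonist activity at Glucose-dependent insulinotropic receptor (Homo sapiens), read by a luciferase reporter, with a stated time of 5 h (on this read-out lower numbers stand for an effect already at smaller amounts and higher numbers for an effect only at larger amounts of compound), gives 300 nM.
Compound 2 `CC(C)OC(=O)N1CCC(COc2ccc(N3CCN(S(=O)(=O)C4CCCCC4)CC3)nc2)CC1` in this assay gives 200 nM.

Of the compounds shown here, two have been measured so far, and they share one core; they differ only in the group attached to the sulfonyl sulfur. Compound 2 shows the lower of the two numbers, but the step of a 1.5-fold lower number from compound 1 to compound 2 (0.18 log units; within the scatter) is small enough to count as ordinary measurement noise, so the two compounds cannot be told apart on these data.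

Compound 3 `CCN(CC)S(=O)(=O)N1CCN(c2ccc(OCC3CCN(C(=O)OC(C)C)CC3)cn2)CC1` is the next compound in the series. The change from compound 2 to compound 3 is diethylamino in place of cyclohexyl on a sulfonyl sulfur. For the measured compounds named here, the only measured step that speaks to this position is the one from compound 1 to compound 2, where a 2-methoxyethyl group was replaced by cyclohexyl at the same sulfonyl sulfur, and that step, a 1.5-fold lower number from compound 1 to compound 2 (0.18 log units; within the scatter), stayed within the scatter. The sulfonyl position has therefore so far tolerated two rather different groups without a clear effect. On this basis a step of about a 1.3-fold higher number from compound 2 to compound 3 (0.10 log units; within the scatter) is expected, which amounts to no change beyond the scatter. Compound 3 is thus estimated at 250 nM, with a likely range from 100 nM to 650 nM.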

Compound 3, half-maximal effective concentration: 1200 nM
Beside the measured number, compound 3's estimate is 4.8-fold (0.68 log units) below it, and the stated range ends below it.
By their numbers in this assay, from the lowest: compounds 2 and 1 (each within the scatter of the next); then compound 3.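

The sulfonyl position is less forgiving than the first two compounds suggested: in this assay, diethylamino in place of cyclohexyl on the sulfonyl sulfur gives a 6.0-fold higher number from compound 2 to compound 3 (0.78 log units; beyond the scatter), and diethylamino in place of 2-methoxyethyl gives a 4.0-fold higher number from compound 1 to compound 3 (0.60 log units; beyond the scatter). Both steps lie beyond the scatter, so this position can influence the read-out, and of the three groups shown, only diethylamino stands apart. The six-membered carbon ring of cyclohexyl is not what separates compound 2 from compound 3 on its own, since 2-methoxyethyl has no ring either and compound 1 remains within the scatter of compound 2, while no measurement shown here explains the difference.

For the compounds shown here, with only three groups on this sulfur, it remains open whether the higher number of compound 3 goes with the nitrogen attached to the sulfonyl sulfur or with the two ethyl chains on that nitrogen. A dimethylamino group, a piperidin-1-yl ring or a plain pentyl chain at the same place would help to separate these two possibilities.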